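Removing the benzyl group from compound 3

The compounds below may be only part of what the source reports. "The series", "measured", "known", "first", "only" and "open" are said of these compounds alone.

- Compound 1 `COCOc1cc(/C=C/C(=O)OCC(=O)Nc2ccc(OC)cc2)ccc1OCc1ccccc1`: 133000 nM
- Compound 2 `COc1ccc(NC(=O)COC(=O)/C=C/c2cc(OC)c(OCc3ccccc3)c(OC)c2)cc1`: > 200000 nM (a limit)
- Compound 3 `COc1ccc(NC(=O)COC(=O)/C=C/c2ccc(OCc3ccccc3)c(O)c2)cc1`: > 200000 nM (a limit)

All three compounds were tested in a functional assay on BEL-7404 cells (Homo sapiens) for cytotoxicity, read by MTT assay, with a stated time of 72 h; on this read-out lower numbers stand for stronger inhibition and higher numbers for weaker inhibition. Compound 3 stands at a limit rather than at a number: it gives > 200000 nM. That reading is the limit of > 200000 nM in this assay, at which 2 of the 3 values shown sit.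

Compound 4 `COc1ccc(NC(=O)COC(=O)/C=C/c2ccc(O)c(O)c2)cc1` arises from compound 3 by one change, hydrogen in place of benzyl on an oxygen on an aromatic ring: benzyloxy becomes hydroxy. Within the data shown here, no measured step removes a benzyl group. The closest one, an at least 1.5-fold higher number from compound 1 to compound 3 (0.17 log units; that floor lies within the scatter), places hydrogen where methoxymethyl stood, so it offers only weak guidance. Compound 1, at 133000 nM, shows that this family can give a true number in this assay. A modest move towards lower numbers is therefore expected, though with little certainty. The expected size is an at least 2.0-fold lower number from compound 3 to compound 4 (0.30 log units; that floor lies within the scatter). For compound 4 the estimate is 100000 nM, with an expected range from 25000 nM to 200000 nM.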

Compound 4, half-maximal inhibitory concentration: > 200000 nM
Compound 4 ended at the assay's limit; the forecaster's own chance of this, stated with the estimate: 35%; middle value at least 2.0-fold (0.30 log units) from the limit.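

Compound 3 and compound 4 both stand at a limit rather than at a true number, so the step between them cannot be read: the limit of > 200000 nM in this assay, at which 3 of the 4 values shown sit.

On these data alone, whether replacing benzyloxy with hydroxy changes the cytotoxicity at all remains open, as does how far either compound lies beyond that limit.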